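A few compounds are considered here, and "the series" means these few. Any claim that something is new, unique, unknown or untested is made for them only; others in the source may bear on it.

Measured so far:
- compound 1 `COc1cc(Cl)cc(-c2nn(-c3cccc(NC(=O)Nc4ccc(Cl)c(C(F)(F)F)c4)c3)cc2-c2ccncc2)c1`: -40%
- compound 2 `COc1cc(Cl)cc(-c2nn(-c3cccc(NC(=O)Nc4cccc(C(F)(F)F)c4)c3)cc2-c2ccncc2)c1`: -74%

Both compounds were tested in a functional assay on MDA-MB-435 cells (Homo sapiens) for inhibition, read by sulforhodamine B assay, with a stated time of 48 h, tested at 100 uM; a higher number here means a weaker effect of the compound at the concentration tested, a lower number a stronger effect. Within the data shown here, on these two numbers compound 2 stands lowest, with compound 1 its only neighbour; the one recorded step, a number 34 percentage points lower from compound 1 to compound 2 (beyond the scatter), shows that a single change in the urea-linked part of the molecule can move the reading a great deal.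

Compound 3 `COc1cc(Cl)cc(-c2nn(-c3cccc(NC(=O)c4cccc(C(F)(F)F)c4)c3)cc2-c2ccncc2)c1` is not yet measured. It differs from compound 2 by 3-(trifluoromethyl)phenyl in place of (3-(trifluoromethyl)phenyl)amino on a carbonyl carbon. Among the measured compounds shown here, no measured step concerns this kind of change: the step from compound 1 to compound 2 alters a substituent, not the linking group itself, so it bears on compound 3 only by showing how sensitive this read-out is to changes in that region. The direction of the expected step is therefore open, and a step of some size in either direction is plausible. Compound 3 is expected to give about -55% in this assay, within -85% to -20%, which means an expected step of a number 19 percentage points higher from compound 2 to compound 3 (beyond the scatter).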

Compound 3, a percentage reported as activity, at one concentration (the size of the read-out at that concentration, not a potency): 52%
For compound 3 the middle estimate is 107 percentage points below the measured one; the whole stated range lies below it.
By their numbers in this assay, from the lowest: compound 2; then compound 1; then compound 3.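

In this assay, the change on the carbonyl carbon gives a number 126 percentage points higher from compound 2 to compound 3 (beyond the scatter), and since a higher number means a weaker effect, replacing (3-(trifluoromethyl)phenyl)amino with 3-(trifluoromethyl)phenyl costs far more of the effect than removing the chloro did. Starting from the chloro-bearing urea, where the chloro is lost as well, the result is a number 92 percentage points higher from compound 1 to compound 3 (beyond the scatter), so both urea compounds read negative while the compound with the plain amide reads positive. Nothing available explains why the linking group matters so much here.

Going by these compounds, it remains open whether a methylene group or a methylated nitrogen in place of that amino nitrogen would read closer to compound 2 or to compound 3. On these data alone, whether a chloro on the ring of compound 3 would shift its reading also remains open.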